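From fluoro to methoxycarbonyl in a cytotoxicity series

A few compounds are considered here, and "the series" means these few. Any claim that something is new, unique, unknown or untested is made for them only; others in the source may bear on it.

Compound 1 `COc1ccc(-c2cc(-c3cc4ccccc4n3C)no2)cc1` gives > 100000 nM in a functional assay on Calu-3 cells (Homo sapiens) for cytotoxicity, read by WST assay, with a stated time of 72 h (a higher number here means a weaker inhibitor, a lower number a stronger inhibitor), which is a limit of the assay and not a number.
Compound 2 `Cn1c(-c2cc(-c3ccc(F)cc3)no2)cc2ccccc21` gives > 100000 nM in this assay, again a limit rather than a number.
Compound 3 `Fc1ccc(-c2cc(-c3ccc4[nH]ccc4c3)on2)cc1` gives 16800 nM in this assay.

Among the measured compounds shown here, compound 3 therefore holds the only number among the three values shown, the other two sitting at the limit of > 100000 nM in this assay, at which 2 of the 3 values shown sit. Nothing in these data ranks compound 3 against compounds 1 and 2 beyond that.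

Compound 4 `COC(=O)c1ccc(-c2cc(-c3ccc4[nH]ccc4c3)on2)cc1` has not yet been measured in this assay. It differs from compound 3 in one place: methoxycarbonyl in place of fluoro on an aromatic carbon. For the measured compounds named here, no two measured compounds differ in a single place, so no measured step offers a precedent for this exchange. The step is expected to be small, most likely within the scatter and without a clear direction, an expected change of a 1.1-fold lower number from compound 3 to compound 4 (0.05 log units; within the scatter). Compound 4 is accordingly estimated at 15000 nM, with a plausible range from 4000 nM to 60000 nM, allowing for some chance that only a limit is reported.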

Compound 4, half-maximal inhibitory concentration: > 100000 nM
Compound 4 was reported as a limit; the forecaster's own chance of this, stated with the estimate: 25%; middle value at least 6.6-fold (0.82 log units) from the limit.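

Methoxycarbonyl in place of fluoro on an aromatic carbon, para to a large group, gives an at least 5.9-fold higher number from compound 3 to compound 4 (0.77 log units; beyond the scatter) in this assay, the only single-place step among the compounds shown. This shows that a change at this one position can carry the series from a measured number to the limit, and the printed size is a minimum, since the value of compound 4 is a limit and not a number. Compound 3 therefore remains the only compound with a number, and the rest share one limit: the limit of > 100000 nM in this assay, at which 3 of the 4 values shown sit.

The compounds shown leave open whether chloro, an amine or a carboxylic acid at this position would stay near compound 3 or also reach the limit. Compound 1 and compound 2 differ from compound 3 in more than one place, so what the rest of the core contributes stays unresolved.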